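Sulfonyl aryl swap in an aryl-sulfone piperidine series

The compounds below may be only part of what the source reports. "The series", "measured", "known", "first", "only" and "open" are said of these compounds alone.

Working notes on the step from compound 1 to compound 3.

Compound 1 `CC1CCN(c2c(S(=O)(=O)c3ccc(Cl)c(Cl)c3)cnc3cc(F)ccc23)CC1` and compound 2 `CC1CCN(c2c(S(=O)(=O)c3ccc(Cl)c(Cl)c3)cnc3cc(Cl)ccc23)CC1` differ only by chloro in place of fluoro on an aromatic carbon. In an assay on isolated protein for displacement of a labelled ligand from metabotropic glutamate receptor 5 (Homo sapiens), with a stated time of 60 min, tested at 1 uM (a lower number here means less inhibition, a higher number more inhibition at the concentration tested (going by the name of the read-out)), compound 1 gives 94%, and compound 2 gives 89%; the change a number 5 percentage points lower from compound 1 to compound 2 (within the scatter) does not separate the two, so compound 1 stands on a par with compound 2 at the upper end of the measured numbers.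

Compound 3 `CC1CCN(c2c(S(=O)(=O)c3cc(F)cc(F)c3)cnc3cc(F)ccc23)CC1` is not yet measured. It differs from compound 1 by 3,5-difluorophenyl in place of 3,4-dichlorophenyl on a sulfonyl sulfur. Going by the values given here, no measured step touches the aryl on the sulfonyl sulfur; the only step in hand, a number 5 percentage points lower from compound 1 to compound 2 (within the scatter), concerns the other aromatic carbon and was within the scatter, so it offers no direct guidance. Because compound 1 sits at 94%, close to the top of the scale, room for a rise is small, while a change of two chlorines for two fluorines on the sulfonyl aryl could well cost inhibition. The expected step is a number 19 percentage points lower from compound 1 to compound 3 (beyond the scatter), a decrease beyond the scatter. Compound 3 is estimated at 75% in this assay, within a range from 40% to 95%.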

Compound 3, a percentage reported as inhibition, at one concentration (the size of the read-out at that concentration, not a potency): 77%
The estimate for compound 3 lay 2 percentage points below the measured number, within the range that was stated.
By their numbers in this assay, from the lowest: compound 3; then compounds 2 and 1 (each within the scatter of the next).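

In this assay, going by these compounds alone, the aryl on the sulfonyl sulfur is the place in this small set where a change clears the scatter: a number 17 percentage points lower from compound 1 to compound 3 (beyond the scatter), while the only other step, a number 5 percentage points lower from compound 1 to compound 2 (within the scatter), stays within it. The two aryl groups match in heavy-atom count and in hydrogen-bond donors and acceptors, yet 3,5-difluorophenyl in place of 3,4-dichlorophenyl gives a modest step, so this position responds to the halogen pattern, although compound 3 still shows clear inhibition at 77%. Within the data shown here, nothing measured so far bears on the reason for this step.

The change alters the halogen and its placement together, so 3,4-difluorophenyl and 3,5-dichlorophenyl would be needed to tell these two contributions apart. Also open, from the compounds shown here alone, is how plain phenyl, or an aryl carrying methoxy or a nitrile, would read at this position, and whether a step of this size would recur with the chloro in place of fluoro found in compound 2.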